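A few compounds are considered here, and "the series" means these few. Any claim that something is new, unique, unknown or untested is made for them only; others in the source may bear on it.

Compound 2 `O=C1CSC(=O)N1C[C@H]1CN(c2ccc(-n3cc(-c4ccccn4)cn3)c(F)c2)C(=O)O1` sits at the limit of an ADME assay on L02 cells (Homo sapiens) for cytotoxicity, read by MTT assay, with a stated time of 48 h (on this read-out higher numbers stand for weaker inhibition and lower numbers for stronger inhibition), where it gives > 400 ug/mL, a limit rather than a number. Compound 1 `COC(=O)CC1CCN(C[C@H]2CN(c3ccc(-n4cc(-c5ccccn5)cn4)c(F)c3)C(=O)O2)CC1` likewise returns only a limit, > 400 ug/mL. Compound 3 `O=C1O[C@@H](Cn2ccnn2)CN1c1ccc(-n2cc(-c3ccccn3)cn2)c(F)c1` gives a measured number, 49 ug/mL. Two of the three values thus rest at the limit of > 400 ug/mL in this assay, at which 2 of the 3 values shown sit. Compound 4 `COC(=O)NC[C@H]1CN(c2ccc(-n3cc(-c4ccccn4)cn3)c(F)c2)C(=O)O1` differs from compound 2 in one place: (methoxycarbonyl)amino in place of 2,4-dioxo-1,3-thiazolidin-3-yl on a saturated chain carbon bound to a saturated ring carbon. The step that the two limits leave unreadable from compound 1 to compound 2 between two limits cannot be read, while an at least 8.1-fold lower number from compound 2 to compound 3 (0.91 log units; beyond the scatter) shows one replacement at this carbon that did move the number. Going by the values given here, only one measured neighbour of compound 2 leaves the limit, so compound 4 is expected to stay near it, with a step of a number no higher from compound 2 to compound 4 (the limit leaves the size open). Compound 4 is therefore estimated at 400 ug/mL, within 150 ug/mL to 800 ug/mL.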

Compound 4, half-maximal inhibitory concentration: 71 ug/mL
Beside the measured number, compound 4's estimate is 5.6-fold (0.75 log units) above it, outside the stated range (below it).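

In this assay, the (methoxycarbonyl)amino group, which has no ring, gives an at least 5.6-fold lower number from compound 2 to compound 4 (0.75 log units; beyond the scatter) and an at least 5.6-fold lower number from compound 1 to compound 4 (0.75 log units; beyond the scatter), so a second replacement on this saturated chain carbon leaves the limit. The 1H-1,2,3-triazol-1-yl group gives a 1.4-fold higher number from compound 3 to compound 4 (0.16 log units; within the scatter), so a group with a ring and one without reach a similar level, while the ring-bearing groups of compound 1 and compound 2 do not. Compound 1 and compound 2 give only limits, so these steps show minimum sizes: the limit of > 400 ug/mL in this assay, at which 2 of the 4 values shown sit.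

The step between compound 1 and compound 2 cannot be read. As far as these compounds go, whether a simple amine or a carboxylic acid on this carbon would stay near compound 3 and compound 4 remains open.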